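The source may report more compounds than this note shows. Statements on the series, on what has been measured and on what is new or still open speak of the compounds shown alone.

Measured compounds:
Compound 1 `CCOC(=O)OC[C@H]1O[C@@H](n2cnc3c(N)ncnc32)[C@H](O)[C@@H]1O` — in an assay on COS-7 cells for inhibition of sodium/nucleoside cotransporter 2 (Homo sapiens), read by scintillation counting, in the presence of a further agent that is not named here (on this read-out lower numbers stand for stronger inhibition and higher numbers for weaker inhibition), compound 1 gives > 100000 nM, a limit of the assay.
Compound 2 `CNC(=O)OC[C@H]1O[C@@H](n2cnc3c(N)ncnc32)[C@H](O)[C@@H]1O` — in this assay compound 2 gives > 100000 nM, a limit of the assay.

Compound 2 therefore stands at a limit, not at a number. Going by the values given here, the only measured step, a step that the two limits leave unreadable from compound 1 to compound 2, replaces ethoxy with methylamino on a carbonyl carbon, and both its ends sit at the limit of > 100000 nM in this assay, at which 2 of the 2 values shown sit, so its size cannot be read. Compound 3 `CCNC(=O)OC[C@H]1O[C@@H](n2cnc3c(N)ncnc32)[C@H](O)[C@@H]1O` differs from compound 2 by methyl in place of hydrogen on a saturated chain carbon bound to an amide-type nitrogen. No measured step touches this kind of change, and the one step known gives no readable size, so the shared core with a carbamate on the primary hydroxyl has shown no inhibition within the range of this assay in either case. For compound 3 the step that the limit leaves unreadable from compound 2 to compound 3 is expected to be none readable beyond the scatter. Compound 3 is estimated at 200000 nM, within 50000 nM to 1000000 nM, most likely reported as a limit.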

Compound 3, half-maximal inhibitory concentration: > 100000 nM
Compound 3: no number, only a limit (the forecaster's own chance of this, stated with the estimate: 90%); the middle value lies beyond the limit too.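

In this assay compound 3 gives > 100000 nM, a limit of the assay. Going by these compounds alone, no step among compound 1, compound 2 and compound 3 can be read: the limit of > 100000 nM in this assay, at which 3 of the 3 values shown sit.

The compounds shown leave open whether any group on this carbonyl carbon of the shared core can give a measurable inhibition.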